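This account rests on a few compounds, and the source may have more. Where it says the series, first, only, none or still open, it means among the compounds named here.

Going by the values given here, compound 3 `O=C(CCC(=O)OCCCCCCSc1ccc([N+](=O)[O-])c2nonc12)NCCN1CCCC1` gives 460 nM in an assay on isolated protein for inhibition of glutathione S-transferase P (Homo sapiens), with a stated time of 10 min (a lower number here means a stronger inhibitor, a higher number a weaker inhibitor), the second highest of the three numbers measured so far: compound 2 `CN(C)CCCNC(=O)CCC(=O)OCCCCCCSc1ccc([N+](=O)[O-])c2nonc12` gives 160 nM, while compound 1 `O=C(CCC(=O)OCCCCCCSc1ccc([N+](=O)[O-])c2nonc12)Nc1ccccc1F` gives 9890 nM. Compound 4 `O=C(CCC(=O)N1CCOCC1)OCCCCCCSc1ccc([N+](=O)[O-])c2nonc12` differs from compound 3 by morpholin-4-yl in place of (2-(pyrrolidin-1-yl)ethyl)amino on a carbonyl carbon. Among the compounds with values here, the steps that bear on this all alter the group on the amide-type nitrogen: a 22-fold lower number from compound 1 to compound 3 (1.33 log units; beyond the scatter), a 62-fold lower number from compound 1 to compound 2 (1.79 log units; beyond the scatter), and a 2.9-fold higher number from compound 2 to compound 3 (0.46 log units; beyond the scatter). Because compound 1, which lacks any 3-(dimethylamino)propyl or 2-(pyrrolidin-1-yl)ethyl chain, gives 9890 nM, removing that chain in compound 4 is expected to weaken inhibition, a 5.4-fold higher number from compound 3 to compound 4 (0.74 log units; beyond the scatter), though probably not all the way back to the level of compound 1. Compound 4 is therefore expected to give 2500 nM, with a range from 800 nM to 8000 nM.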

Compound 4, half-maximal inhibitory concentration: 330 nM
Compound 4: middle estimate off by 7.6-fold (0.88 log units), on the high side, outside the stated range (below it).
By their numbers in this assay, from the lowest: compound 2; then compounds 4 and 3 (each within the scatter of the next); then compound 1.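

In this assay, morpholin-4-yl and (2-(pyrrolidin-1-yl)ethyl)amino on this carbonyl carbon cannot be told apart, a 1.4-fold lower number from compound 3 to compound 4 (0.14 log units; within the scatter). Compound 4 has neither the 2-(pyrrolidin-1-yl)ethyl nor the 3-(dimethylamino)propyl chain, yet it shows a 30-fold lower number from compound 1 to compound 4 (1.48 log units; beyond the scatter), so among these compounds a low number does not require such a chain, although a 2.1-fold higher number from compound 2 to compound 4 (0.31 log units; beyond the scatter). From the compounds shown here alone, it remains open whether the high number of compound 1 belongs to the 2-fluorophenyl group specifically or to any aromatic ring on that nitrogen, which a plain phenyl or a piperidin-1-yl group at this position could test. No supporting evidence bears on the reason for these steps.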